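Trifluoromethyl to chloro on the terminal aryl urea

The source may hold more compounds than are shown below. What is called first, only, known or untested is meant among the compounds shown, and "the series" means these compounds.

Compound 2 `COc1cc2cc(Oc3ccc(NC(=O)Nc4ccc(Cl)c(C(F)(F)F)c4)cc3)c(C)nc2cc1OC` is measured in a functional assay on M14 cells (Homo sapiens) for inhibition, read by sulforhodamine B assay, with a stated time of 48 h (on this read-out lower numbers stand for higher toxicity in this test and higher numbers for lower toxicity in this test), and gives 19200 nM. Among the compounds with values here, that is the lower of the two numbers so far; the nearest is compound 1 `COc1cc2cc(Oc3ccc(NC(=O)Nc4cccc(C(F)(F)F)c4)cc3)c(C)nc2cc1OC`, which in this assay gives 35600 nM. Within the data shown here, the step of a 1.9-fold lower number from compound 1 to compound 2 (0.27 log units; within the scatter) is the only measured step.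

Compound 3 `COc1cc2cc(Oc3ccc(NC(=O)Nc4ccc(Cl)c(Cl)c4)cc3)c(C)nc2cc1OC` has not yet been measured. Its change from compound 2 is chloro in place of trifluoromethyl on an aromatic carbon. Among the measured compounds shown here, no measured step covers this exchange: the only step known, a 1.9-fold lower number from compound 1 to compound 2 (0.27 log units; within the scatter), concerns chloro in place of hydrogen and stayed within the scatter, so it offers only a general indication that small changes at this ring have so far moved this assay little.

With nothing more to go on, the expectation is a step of a 1.1-fold higher number from compound 2 to compound 3 (0.06 log units; within the scatter), that is no movement beyond the scatter in this assay. For compound 3 the estimate in this assay is therefore 22000 nM, with a range from 9000 nM to 55000 nM, the wide band reflecting the absence of a directly comparable measured step.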

Compound 3, concentration lethal to 50% of the cells: 34700 nM
The estimate for compound 3 lay 1.6-fold (0.20 log units) below the measured number, and the stated range covers the measured number.
By their numbers in this assay, from the lowest: compounds 2, 3 and 1 (each within the scatter of the next).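

In this assay, within the data shown here, the first exchange at the position ortho to a chloro group, chloro in place of trifluoromethyl, gives a 1.8-fold higher number from compound 2 to compound 3 (0.26 log units; within the scatter) and so stays inside the scatter, even though 1 heavy atom replaces a group of 4 heavy atoms. Among these compounds, the wider comparison, a 1.0-fold lower number from compound 1 to compound 3 (0.01 log units; within the scatter) on exchanging 3-(trifluoromethyl)phenyl for 3,4-dichlorophenyl on the amide-type nitrogen, also stays inside the scatter, so these three terminal aryl groups cannot be told apart in this test, and the series so far reads as flat at this ring. No accompanying measurement offers an explanation for this flat result.

From the compounds shown here alone, it remains open whether a group of a different kind at this position, such as a carboxylic acid, an amine or a longer chain, would give a step beyond the scatter. Also open, going by these compounds, is whether a change away from this ring, for example a longer alkoxy chain in place of a methoxy group on the shared core, would move the number more than the exchanges seen here.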